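This account rests on a few compounds, and the source may have more. Where it says the series, first, only, none or still open, it means among the compounds named here.

Measured in a functional assay on PC-3 cells (Homo sapiens) for antiproliferative activity, read by MTT assay, with a stated time of 48 h; a lower number here means a stronger inhibitor, a higher number a weaker inhibitor:

Compound 1, `Cc1cnc(Nc2ccc(S(C)(=O)=O)cc2)nc1Nc1nc2ccc(Cl)cc2s1`, gives 13400 nM.
Compound 2, `NS(=O)(=O)c1ccc(Nc2ncc(F)c(Nc3nc4ccc(Cl)cc4s3)n2)cc1`, gives 1430 nM.
Compound 3, `Cc1cnc(Nc2ccc(S(N)(=O)=O)cc2)nc1Nc1nc2ccc(Cl)cc2s1`, gives 5400 nM.

Among these three numbers compound 3 stands second highest. Its nearest neighbour is compound 1, and the step between them, a 2.5-fold lower number from compound 1 to compound 3 (0.39 log units; beyond the scatter), comes from putting an amino group in place of a methyl group on the sulfonyl sulfur. Its furthest neighbour is compound 2, and that step, a 3.8-fold higher number from compound 2 to compound 3 (0.58 log units; beyond the scatter), comes from putting a methyl group in place of a fluoro group on an aromatic carbon of the shared core.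

Compound 4, `Cc1cnc(Nc2ccc(S(N)(=O)=O)cc2)nc1Nc1nc2ccc(F)cc2s1`, differs from compound 3 at a third place: fluoro in place of chloro on an aromatic carbon. Neither measured step touches this position; both change groups elsewhere, so they give no direct guide to the size or direction of this swap. With nothing in the shown data pointing one way, the expectation for this assay is a step that stays within the usual scatter, a 1.2-fold higher number from compound 3 to compound 4 (0.08 log units; within the scatter), with only a slight lean toward a higher number. Compound 4 is therefore estimated at 6500 nM, within a range from 2500 nM to 17000 nM.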

Compound 4, half-maximal inhibitory concentration: 6980 nM
Beside the measured number, compound 4's estimate is 1.1-fold (0.03 log units) below it; the measured number falls inside the stated range.
By their numbers in this assay, from the lowest: compound 2; then compounds 3, 4 and 1 (each within the scatter of the next, the first and the last beyond it).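

In this assay, the step that changes this position is a 1.3-fold higher number from compound 3 to compound 4 (0.11 log units; within the scatter), so trading chloro for fluoro on this aromatic carbon, on a ring that is part of a fused system, leaves the reading indistinguishable from that of compound 3. Among these compounds, this is the first look at this position, and it sets it apart from the two earlier single changes, on the sulfonyl sulfur and on the aromatic carbon of the shared core, each of which gave a step beyond the scatter. Nothing available explains why this swap behaves as it does, so the result stands as an observation only.

Among the compounds shown here, this position is seen here with only two groups, chloro and fluoro, each a single heavy atom, so a larger group such as methoxy, an amine or a longer chain could give a quite different reading. On these data alone, it also remains open whether the same swap would stay within the scatter on the core of compound 2, which carries fluoro rather than methyl on its other aromatic carbon.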